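The source may report more compounds than this note shows. Statements on the series, on what has been measured and on what is new or still open speak of the compounds shown alone.

Measured compounds:
- compound 1 `C=CCn1ncc2c(C)nc(C(C)C)n2c1=O` — in a functional assay for inhibition, with Homo sapiens as the target (a higher number here means a weaker inhibitor, a lower number a stronger inhibitor), compound 1 gives > 48000 nM, a limit of the assay.
- compound 2 `C=CCn1ncc2c(CC)ncn2c1=O` — in this assay compound 2 gives > 48000 nM, also a limit.
- compound 3 `C=CCn1ncc2c(C)nc(C(C)(C)C)n2c1=O` — in this assay compound 3 gives > 48000 nM, again a limit.

Compound 3 thus stands at the limit that every measured compound shares, as noted in the limit of > 48000 nM in this assay, at which 3 of the 3 values shown sit. For the measured compounds named here, the one measured step that touches the same place, a step that the two limits leave unreadable from compound 1 to compound 3, runs between two limits and so cannot be read.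

The next compound, compound 4 `C=CCn1ncc2c(C)ncn2c1=O`, differs from compound 3 by hydrogen in place of tert-butyl on an aromatic carbon. Compound 2 also carries hydrogen at that aromatic carbon, with ethyl rather than methyl on its core, and it sits at the limit like the others. Going by the values given here, no measured step can therefore be read for this change, and nothing points to a move beyond the scatter in this assay. The step that the limit leaves unreadable from compound 3 to compound 4 is estimated as essentially none, with a high chance that only a limit is again reported. Compound 4 is expected to give 60000 nM, within 20000 nM to 200000 nM.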

Compound 4, half-maximal inhibitory concentration: > 48000 nM
Compound 4 gave a limit, no number; the forecaster's own chance of this, stated with the estimate: 85%; the middle value lies beyond the limit too.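

Compound 4 also ends at a limit, so its steps from compound 1, compound 2 and compound 3 cannot be read, and the four compounds share one result: the limit of > 48000 nM in this assay, at which 4 of the 4 values shown sit. The compounds shown leave open which change to the shared core, if any, would give a readable number in this assay rather than a limit.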